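A methyl added to the phenyl ring of compound 1

A few compounds are considered here, and "the series" means these few. Any claim that something is new, unique, unknown or untested is made for them only; others in the source may bear on it.

In a functional assay on MCF7 cells (Homo sapiens) for inhibition, read by MTT assay, with a stated time of 24 h, tested at 10 uM (a lower number here means less inhibition of growth, a higher number more inhibition of growth at the concentration tested), compound 1 `CS(=O)(=O)c1ccc(-c2cnc3[nH]cc(-c4nnc(-c5ccccc5)o4)c(=O)c3c2)cc1` gives 2.83%, the lowest of three numbers; compound 2 `N#Cc1ccc(-c2cnc3[nH]cc(-c4nnc(-c5ccc(Cl)cc5)o4)c(=O)c3c2)cc1` gives 19.7% and compound 3 `O=c1c(-c2nnc(-c3ccc(Cl)cc3)o2)c[nH]c2ncc(-c3ccccc3)cc12` gives 26.9%, both beyond the scatter above it. Compound 4 `Cc1cccc(-c2nnc(-c3c[nH]c4ncc(-c5ccc(S(C)(=O)=O)cc5)cc4c3=O)o2)c1` carries methyl in place of hydrogen on an aromatic carbon, meta to a large group. Among the compounds with values here, no measured step touches this phenyl ring; the only single-point step, a number 7.2 percentage points higher from compound 2 to compound 3 (within the scatter), sits on the other aryl group and stays within the scatter, so it offers a loose parallel at best. Compound 4 is therefore expected to give 6%, within -5% to 20%. The estimated step, a number 3.2 percentage points higher from compound 1 to compound 4 (within the scatter), is expected to stay within the scatter.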

Compound 4, percent growth inhibition at one concentration: 7.76%
The estimate for compound 4 lay 1.8 percentage points below the measured number; measured number inside the range.
By their numbers in this assay, from the lowest: compounds 1 and 4 (each within the scatter of the next); then compounds 2 and 3 (each within the scatter of the next).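

In this assay, within the data shown here, the change from phenyl to 3-methylphenyl gives a number 4.9 percentage points higher from compound 1 to compound 4 (within the scatter) on a ring that no earlier step touched. A methyl meta to a large group on this ring therefore leaves the reading indistinguishable from that of compound 1, with no sign of a gain in growth inhibition at the concentration tested. No available evidence bears on this result.

Going by these compounds, whether a methoxy, an amine or a carboxylic acid at this place would move the number beyond the scatter remains open. So does whether a methyl here would behave alike with a chlorine on this ring.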